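The source may report more compounds than this note shows. Statements on the series, on what has been measured and on what is new or still open speak of the compounds shown alone.

Measured so far:
compound 1, `CCN1CCN(c2cc(Nc3cc(C)nn3C(=O)C(C)(C)C)nc(N[C@H]3CCN(C(=O)c4ccc(Cl)cc4F)C3)n2)CC1` — 59 nM
compound 2, `CCOC(=O)n1nc(Nc2cc(N3CCN(CC)CC3)nc(N[C@H]3CCN(C(=O)c4ccc(Cl)cc4F)C3)n2)cc1C` — 457 nM

Compound 2 gives the highest of the two numbers in an ADME assay on the whole organism (Mus musculus, strain ICR) for pharmacokinetics, read by LC-MS, with a stated time of 24 h, at a dose of 10 mg/kg by the oral route (on this read-out lower numbers stand for lower exposure and higher numbers for higher exposure at the dose given), and its nearest neighbour, compound 1, sits a clear step below it: a 7.7-fold higher number from compound 1 to compound 2 (0.89 log units; beyond the scatter). That step swapped one group on the aromatic nitrogen of the shared core for another, 1-(ethoxycarbonyl)-5-methyl-1H-pyrazol-3-yl in place of 3-methyl-1-((tert-butyl)carbonyl)-1H-pyrazol-5-yl.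

Compound 3, `CCN1CCN(c2cc(Nc3cc(C)[nH]n3)nc(N[C@H]3CCN(C(=O)c4ccc(Cl)cc4F)C3)n2)CC1`, goes one step further from compound 2: hydrogen in place of ethoxycarbonyl on an aromatic nitrogen. Among the measured compounds shown here, the only measured step, from compound 1 to compound 2, concerns the same aromatic nitrogen but exchanges one substituent for another rather than removing it, so it bears on the new step only loosely. For the measured compounds named here, no measured pair shows what a bare 5-methyl-1H-pyrazol-3-yl does here, and the expectation for compound 3 is therefore a broad one. Compound 3 is expected to give 250 nM in this assay, between 50 nM and 1200 nM, a step of a 1.8-fold lower number from compound 2 to compound 3 (0.26 log units; within the scatter) that is expected to lie within or just beyond the scatter.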

Compound 3, maximal plasma concentration: 748 nM
Beside the measured number, compound 3's estimate is 3.0-fold (0.48 log units) below it; low and high end bracket the measured number.
By their numbers in this assay, from the lowest: compound 1; then compounds 2 and 3 (each within the scatter of the next).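

In this assay the ethoxycarbonyl group on the aromatic nitrogen can give way to hydrogen with no change beyond the scatter, a 1.6-fold higher number from compound 2 to compound 3 (0.21 log units; within the scatter), so compound 2 and compound 3 cannot be told apart on this read-out. The bare 5-methyl-1H-pyrazol-3-yl also stands well clear of the group in compound 1, a 13-fold higher number from compound 1 to compound 3 (1.10 log units; beyond the scatter), which leaves compound 1 as the only one of the three set apart. Nothing measured here accounts for these numbers.

The step from compound 1 exchanges the (tert-butyl)carbonyl group and the point of attachment of the pyrazole together, so these compounds do not separate the two. On these data alone, how a methyl or an acetyl group on the same aromatic nitrogen would read also remains open.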